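Dichlorophenyl for benzyl on the lactam nitrogen: solubility

This account rests on a few compounds, and the source may have more. Where it says the series, first, only, none or still open, it means among the compounds named here.

In a physicochemical assay for solubility, in phosphate buffer (on this read-out lower numbers stand for lower solubility and higher numbers for higher solubility), compound 1 `O=C(NO)c1ccc(OC2CCN(c3ccccc3)C2=O)cc1` gives 203 ug/mL. Compound 2 `O=C(NO)c1ccc(NC2CCN(Cc3ccccc3)C2=O)cc1` returns only > 385 ug/mL, which is a limit of this assay and not a number, so its standing is known only as a limit, as recorded by the limit of > 385 ug/mL in this assay, at which 1 of the 2 values shown sits. Compound 3 `O=C(NO)c1ccc(NC2CCN(c3ccc(Cl)c(Cl)c3)C2=O)cc1` differs from compound 2 by 3,4-dichlorophenyl in place of benzyl on an amide-type nitrogen in a ring. Among the measured compounds shown here, no measured step covers this change. The step of an at least 9.6-fold lower number from compound 2 to compound 3 (0.98 log units; beyond the scatter) is expected to run downward, beyond the usual scatter. For compound 3 in this assay the estimate is 40 ug/mL, with a range of 10 ug/mL to 150 ug/mL.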

Compound 3, solubility: < 1 ug/mL
Compound 3: a limit, no number; the forecaster's own chance of this, stated with the estimate: 5%; middle value at least 40-fold (1.60 log units) away from the limit.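

Among the compounds shown here, this is the first step that reads a single change on the amide-type nitrogen in a ring: 3,4-dichlorophenyl in place of benzyl gives an at least 380-fold lower number from compound 2 to compound 3 (2.58 log units; beyond the scatter) in this assay. Compound 2 gives only a limit, > 385 ug/mL. Compound 3 also gives only a limit, < 1 ug/mL, so this position can move the read-out across the whole span of this assay.

Going by these compounds, the full size of the step stays open, as does whether the chlorine atoms or the change from benzyl to an aryl group directly on the nitrogen carries it. A 3,4-dichlorobenzyl or a pyridyl group on this nitrogen would help separate the two.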